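Primary Amide Variant of a Cyclohexene Carboxamide Bcl-2 Inhibitor

The source may hold more compounds than are shown below. What is called first, only, known or untested is meant among the compounds shown, and "the series" means these compounds.

Measured compounds:
- compound 1 `CC(C)=CCCC1=CC[C@H](C(=O)Nc2ccc(O)cc2)[C@@H](c2ccccc2)C1`: > 23000 nM in an assay on isolated protein for inhibition of Apoptosis regulator Bcl-2 (Homo sapiens), read by fluorescence polarization, with stated times of 5 min and 10 min (on this read-out higher numbers stand for weaker inhibition and lower numbers for stronger inhibition), a limit of the assay
- compound 2 `CC(C)=CCCC1=CC[C@H](C(=O)Nc2ccc(C(=O)O)cc2)[C@@H](c2ccccc2)C1`: > 23000 nM in this assay, a limit of the assay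
- compound 3 `CC(C)=CCCC1=CC[C@H](C(=O)N(C)O)[C@@H](c2ccccc2)C1`: 2100 nM in this assay

Compound 3 is the only one of the three that gives an actual number in this assay; compounds 1 and 2 sit at the limit of > 23000 nM in this assay, at which 2 of the 3 values shown sit. The two steps that end at compound 3, an at least 10-fold lower number from compound 1 to compound 3 (1.03 log units; beyond the scatter) and an at least 10-fold lower number from compound 2 to compound 3 (1.03 log units; beyond the scatter), both show that the hydroxy(methyl)amino group at the carbonyl carbon goes with a much lower number than either aryl amino group.

Compound 4 `CC(C)=CCCC1=CC[C@H](C(N)=O)[C@@H](c2ccccc2)C1` differs from compound 3 by amino in place of hydroxy(methyl)amino on a carbonyl carbon. Going by the values given here, no measured step removes the hydroxy and methyl from this nitrogen, so the measured steps give no direct guide to its size or direction. The expectation is therefore a step toward a higher number, a 3.8-fold higher number from compound 3 to compound 4 (0.58 log units; beyond the scatter), with wide uncertainty. Compound 4 is estimated at 8000 nM, between 2000 nM and 30000 nM.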

Compound 4, inhibition constant: > 23000 nM
Compound 4 gave a limit, no number (the forecaster's own chance of this, stated with the estimate: 40%); at least 2.8-fold (0.45 log units) between middle value and limit.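

Removing the hydroxy and methyl from the nitrogen to leave a plain amino group on the carbonyl carbon gives an at least 10-fold higher number from compound 3 to compound 4 (1.03 log units; beyond the scatter). The earlier compounds compared hydroxy(methyl)amino only with two aryl amino groups, whereas compound 4 has no aryl group on this nitrogen and still gives no number, so among the compounds shown, dropping the aryl group alone is not enough for a measurable value in this assay. The steps from compound 1 and compound 2 to compound 4 cannot be read, as all three compounds sit at the same limit of the assay: the limit of > 23000 nM in this assay, at which 3 of the 4 values shown sit.

As far as these compounds go, what stays open is which part of the hydroxy(methyl)amino group goes with the lower number. Compounds carrying a hydroxyamino group or a methylamino group on the carbonyl carbon would separate the hydroxy from the methyl.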